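The source may hold more compounds than are shown below. What is called first, only, known or untested is meant among the compounds shown, and "the series" means these compounds.

Of the compounds shown here, three built on one shared core have been tested in a functional assay on the whole organism (strain CD1) with Mus musculus as the target, in the maximal electroshock model, with a stated time of 0.5 h; a higher number here means that more compound is needed for the effect, a lower number that less compound is needed. Compound 1 `CC1CC(=O)N(CC(=O)N2CCN(c3ccccc3)CC2)C1=O` gives 300 mg/kg. Compound 2 `CCC1(C)CC(=O)N(CC(=O)N2CCN(c3ccccc3Cl)CC2)C1=O` gives 100 mg/kg. Compound 3 `Cc1cccc(N2CCN(C(=O)CN3C(=O)CC(C)C3=O)CC2)c1` gives 300 mg/kg. Compound 3 stands level with compound 1, the two together at the highest number of the three, while compound 2 needs a lower dose than either.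

Compound 4 `CC1CC(=O)N(CC(=O)N2CCN(c3ccc(F)cc3)CC2)C1=O` has not yet been measured. It differs from compound 3 in a single place: 4-fluorophenyl in place of 3-methylphenyl on an amine nitrogen in a ring. Within the data shown here, only one measured step bears on such a change of the group on the aromatic ring: no change at the digits printed from compound 1 to compound 3 (within the scatter), so adding a methyl on an aromatic carbon left the dose where it was. Compound 2 carries a chlorine on its aromatic ring, but it also differs at the core, so nothing about the ring alone can be read from it.

Among the measured compounds shown here, with one unchanged step as the only guide, compound 4 is expected to show no change at the digits printed from compound 3 to compound 4 (within the scatter), meaning no movement beyond the scatter. The estimate for compound 4 in this assay is therefore 300 mg/kg, within a range from 100 mg/kg to 600 mg/kg.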

Compound 4, minimum effective dose: 300 mg/kg
For compound 4 middle estimate and measured number coincide at the digits printed; the range from low to high includes it.
By their numbers in this assay, from the lowest: compound 2; then compounds 1, 3 and 4 (each within the scatter of the next).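

In this assay, putting a fluorine on the aromatic ring gives no change at the digits printed from compound 1 to compound 4 (within the scatter) for this change, so a second kind of group on the aromatic ring, not only a methyl, leaves the dose where it stood. Replacing 3-methylphenyl with 4-fluorophenyl on the amine nitrogen in the ring gives no change at the digits printed from compound 3 to compound 4 (within the scatter) for this swap, so a different group at a different place on that ring also reads the same in compounds 1, 3 and 4. Nothing available explains why these groups read alike.

Still open, from the compounds shown here alone, is whether an amine, a carboxylic acid or a longer chain on this aromatic ring would move the dose at all. Also open, going by these compounds, is what a chlorine alone would do on the core of compound 1.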